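The source may report more compounds than this note shows. Statements on the series, on what has been measured and on what is new or still open speak of the compounds shown alone.

Of the compounds shown here, three sharing one core have been measured in a functional assay on the whole organism (strain CF-1) for inhibition, with Mus musculus as the target; a higher number here means that more compound is needed for the effect, a lower number that less compound is needed. Compound 1 `Cc1nnc(CN(C)C)n1-c1ccc(Cl)cc1C(=O)c1ccccc1` gives 1.1 mg/kg in this assay, compound 2 `Cc1nnc(CN(C)C)n1-c1ccccc1C(=O)c1ccccc1Cl` gives 7 mg/kg, and compound 3 `Cc1nnc(CN(C)C)n1-c1ccc(Cl)cc1C(=O)c1ccccc1Cl` gives 0.28 mg/kg. Compound 3 therefore stands with the lowest number of the three: the step of a 3.9-fold lower number from compound 1 to compound 3 (0.59 log units; beyond the scatter) is modest, and the step of a 25-fold lower number from compound 2 to compound 3 (1.40 log units; beyond the scatter) is large. Both of these steps come from chloro in place of hydrogen on an aromatic carbon, and both lie beyond the scatter.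

Compound 4 `CN(C)Cc1nnc(C2CC2)n1-c1ccc(Cl)cc1C(=O)c1ccccc1Cl` differs from compound 3 in one place: cyclopropyl in place of methyl on an aromatic carbon. Neither of the two measured steps touches this methyl group; each concerns a chloro substituent on a different part of the core. Within the data shown here, no measured step therefore bears directly on the exchange of methyl for cyclopropyl, and the data give no direction for it. In the absence of any guiding comparison, the change is expected to give no step beyond the scatter in this assay. The step from compound 3 to compound 4 is thus expected to be a 1.3-fold higher number from compound 3 to compound 4 (0.10 log units; within the scatter). Compound 4 is estimated at 0.35 mg/kg in this assay, with a range from 0.1 mg/kg to 1.2 mg/kg, the width of the range reflecting that the data hold no comparable change.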

Compound 4, dose for half-maximal effect: 1 mg/kg
The estimate for compound 4 lay 2.9-fold (0.46 log units) below the measured number, and the stated range covers the measured number.
By their numbers in this assay, from the lowest: compound 3; then compounds 4 and 1 (each within the scatter of the next); then compound 2.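

In this assay, the place on the aromatic carbon between two ring nitrogen atoms, which none of the chloro steps had touched, proves sensitive to its substituent: cyclopropyl in place of methyl gives a 3.6-fold higher number from compound 3 to compound 4 (0.55 log units; beyond the scatter). The exchange replaces one carbon with three carbons and a three-membered ring, adds no hydrogen-bond donor or acceptor and no net charge, and moves the number towards more compound being needed for the effect. Nothing in the data explains why the number moves in this direction.

On these data alone, with only methyl and cyclopropyl at this place, it remains open whether the higher number follows the added carbons or the ring itself; an ethyl or isopropyl group, which carries added carbons without that ring, or a plain hydrogen would help to separate the two. Among these compounds, it also remains open whether cyclopropyl would give a step of the same size without the two chloro substituents, since here the exchange is seen only in a compound that carries both of them.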